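The source may hold more compounds than are shown below. What is called first, only, known or untested is meant among the compounds shown, and "the series" means these compounds.

Compound 1 `O=C(C1CCN(C(=O)C(F)(F)F)CC1)N1N=CCC1c1ccccc1`: > 1.5 h
Compound 2 `O=C(c1cn[nH]c1)N1CCC(C(=O)N2N=CCC2c2ccccc2)CC1`: > 2.75 h

In an ADME assay on microsomes (Homo sapiens) for metabolic stability (on this read-out higher numbers stand for a longer-lived compound and lower numbers for a shorter-lived compound), compound 2 gives > 2.75 h, which is a limit of the assay and not a number. Compound 1 gives > 1.5 h, which is also a limit. These two limits do not place compound 2 in any order.

The next structure is compound 3 `O=C(C1CCN(c2ccccc2)CC1)N1N=CCC1c1ccccc1`, which differs from compound 2 like this: phenyl in place of (1H-pyrazol-4-yl)carbonyl on an amine nitrogen in a ring.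

Among the compounds with values here, only one measured step exists, a step that the two limits leave unreadable from compound 1 to compound 2. It cannot be read for size, and it changes a group on a carbonyl carbon while that carbonyl stays in place. Within the data shown here, compound 3 loses this carbonyl, so the new change has no measured precedent. A shorter half-life in this assay is only a cautious expectation, and its size is uncertain. The expected change is an at least 1.8-fold lower number from compound 2 to compound 3 (0.26 log units; that floor lies within the scatter). For compound 3 the estimated half-life is 1.5 h, with an expected range from 0.5 h to 4 h.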

Compound 3, half-life: > 1.5 h
Compound 3: a limit, no number; the forecaster's own chance of this, stated with the estimate: 35%; the middle value sits exactly at the limit.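

In this assay compound 3 gives > 1.5 h, which is a limit of the assay and not a number. Within the data shown here, compound 1 and compound 2 also carry limits, so no step among the three compounds can be read. The compounds shown leave open how long each half-life actually is and which of the three lasts longest.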